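Benzyl for allyl on the amine of compound 2

The source may hold more compounds than are shown below. What is called first, only, known or untested is meant among the compounds shown, and "the series" means these compounds.

Compound 1 `CCCCN(C)Cc1c(C(F)(F)F)nc2n(-c3c(C)cc(C)cc3C)c(Cl)cn12`: 310 nM
Compound 2 `C=CCN(CCC)Cc1c(C(F)(F)F)nc2n(-c3c(C)cc(C)cc3C)c(Cl)cn12`: 4.5 nM
Compound 3 `Cc1cc(C)c(-n2c(Cl)cn3c(CN(CCC(F)(F)F)Cc4ccc(Cl)cc4)c(C(F)(F)F)nc23)c(C)c1`: 12 nM

Three compounds share one core and differ only in the two groups on the amine nitrogen. In an assay on cells for displacement of a labelled ligand from corticotropin-releasing factor receptor 1 (Homo sapiens), with a stated time of 100 min (a higher number here means a weaker inhibitor, a lower number a stronger inhibitor), compound 1 gives 310 nM, compound 2 gives 4.5 nM and compound 3 gives 12 nM. Among the measured compounds shown here, compound 2 has the lowest number of the three: its nearest neighbour is compound 3, and the gap to compound 1 is far larger, as the only measured step, a 69-fold lower number from compound 1 to compound 2 (1.84 log units; beyond the scatter), shows.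

Compound 4 `CCCN(Cc1ccccc1)Cc1c(C(F)(F)F)nc2n(-c3c(C)cc(C)cc3C)c(Cl)cn12` has not been measured. It differs from compound 2 in one place: phenyl in place of vinyl on a saturated chain carbon bound to an amine nitrogen. For the measured compounds named here, no measured step covers this exact change. Going by the values given here, the only measured step, a 69-fold lower number from compound 1 to compound 2 (1.84 log units; beyond the scatter), concerns the other end of the amine, so it does not bear on it directly. Compound 3, which carries a ring on one arm of the amine, stands close to compound 2 in this assay, so a ring at this position seems tolerated. Compound 4 is therefore expected to stay near compound 2, with a step of a 1.8-fold higher number from compound 2 to compound 4 (0.25 log units; within the scatter), and its estimated value is 8 nM, within a range from 2.5 nM to 25 nM.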

Compound 4, inhibition constant: 170 nM
Compound 4: middle estimate off by 21-fold (1.33 log units), on the low side, outside the stated range (above it).
By their numbers in this assay, from the lowest: compound 2; then compound 3; then compounds 4 and 1 (each within the scatter of the next).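

With propyl kept on the amine, benzyl in place of allyl is a heavy change in this assay, giving a 38-fold higher number from compound 2 to compound 4 (1.58 log units; beyond the scatter), so the low number of compound 2 does not survive this exchange of a vinyl end for a phenyl end. The step of a 1.8-fold lower number from compound 1 to compound 4 (0.26 log units; within the scatter) shows that benzyl(propyl)amino and butyl(methyl)amino cannot be told apart here, which leaves compound 2 alone among these three closely related amines. Nothing measured here accounts for the loss.

Compound 3 differs from compound 4 on both arms of the amine, so it cannot show whether a ring on this arm is acceptable only alongside another partner. Nor do these compounds show how a cyclopropylmethyl group or a pyridylmethyl group on this arm would fare with propyl kept in place.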